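Swapping Chloro for Fluoro on a Triazolothiadiazine Pendant Ring

The compounds below may be only part of what the source reports. "The series", "measured", "known", "first", "only" and "open" are said of these compounds alone.

Measured compounds:
- compound 1, `CC(c1ccc(-c2ccccc2)c(F)c1)c1nnc2n1N=C(c1ccc(Cl)cc1)CS2`: 8700 nM
- compound 2, `CC(c1ccc(-c2ccccc2)c(F)c1)c1n[nH]c(=S)n1N`: "not active" (no number reported)
- compound 3, `Cc1ccc(C2=Nn3c(nnc3C(C)c3ccc(CC(C)C)cc3)SC2)cc1`: 6300 nM

In a functional assay on MCF7 cells (Homo sapiens) for inhibition, read by sulforhodamine B assay, with a stated time of 72 h (on this read-out lower numbers stand for stronger inhibition and higher numbers for weaker inhibition), compound 1 gives 8700 nM, the highest of the two numbers reported, though compound 3 at 6300 nM lies within the scatter of it, so no order can be read between the two. Compound 2 is reported as not active with no number.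

Compound 4, `CC(c1ccc(-c2ccccc2)c(F)c1)c1nnc2n1N=C(c1ccc(F)cc1)CS2`, is not yet measured. It differs from compound 1 by fluoro in place of chloro on an aromatic carbon.

Among the compounds with values here, no measured pair of compounds shows this change, so its size cannot be read from the data. The expectation is a small step, if any, toward a weaker inhibition, largely within the scatter.

For compound 4 the estimated value is 12000 nM, with a range from 4000 nM to 36000 nM.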

Compound 4, half-maximal inhibitory concentration: 8100 nM
Compound 4: middle estimate off by 1.5-fold (0.17 log units), on the high side; measured number inside the range.
By their numbers in this assay, from the lowest: compounds 3, 4 and 1 (each within the scatter of the next).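

In this assay, within the data shown here, the 4-chlorophenyl to 4-fluorophenyl exchange gives the first direct reading at this position: a 1.1-fold lower number from compound 1 to compound 4 (0.03 log units; within the scatter), a step within the usual scatter. On this core and in this assay, chloro and fluoro at this place cannot be told apart. Nothing at hand gives a reason for this result.

The compounds shown compare only these two halogens at this place. On these data alone, whether a methoxy group, an amine or a carboxylic acid on the same ring would move the number stays open.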